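From Thiomorpholin-4-yl to Piperidin-1-yl on Compound 1

This account rests on a few compounds, and the source may have more. Where it says the series, first, only, none or still open, it means among the compounds named here.

Compound 1 `Cc1ccnc(/C(N)=N/NC(=S)N2CCSCC2)c1` gives 15500 nM in a functional assay on HeLa cells (Homo sapiens) for cytotoxicity, read by MTT assay, with a stated time of 72 h (on this read-out lower numbers stand for stronger inhibition and higher numbers for weaker inhibition), the highest of the three numbers shown. Compound 2 `N/C(=N\NC(=S)N1CCSCC1)c1ccccn1` gives 7800 nM in the same assay, and the step reads a 2.0-fold lower number from compound 1 to compound 2 (0.30 log units; within the scatter). Compound 3 `Cc1ccnc(/C(N)=N/NC(=S)N2CCCCCC2)c1` gives 7000 nM in this assay, a gap to compound 1 that lies beyond the scatter. Compound 4 `Cc1ccnc(/C(N)=N/NC(=S)N2CCCCC2)c1` differs from compound 1 by piperidin-1-yl in place of thiomorpholin-4-yl on a thiocarbonyl carbon. No measured step exchanges this ring: the only step shown, at an aromatic carbon, stays within the scatter, while the values of compound 1 and compound 3 show that a change at the thiocarbonyl carbon can lower the number beyond it. Compound 4 is therefore expected to give 9000 nM in this assay, between 4000 nM and 22000 nM. The expected step is a 1.7-fold lower number from compound 1 to compound 4 (0.24 log units; within the scatter).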

Compound 4, half-maximal inhibitory concentration: 7700 nM
The estimate for compound 4 lay 1.2-fold (0.07 log units) above the measured number, and the stated range covers the measured number.
By their numbers in this assay, from the lowest: compounds 3, 4, 2 and 1 (each within the scatter of the next, the first and the last beyond it).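

In this assay, going by these compounds alone, the first direct exchange of this ring on the thiocarbonyl carbon reads a 2.0-fold lower number from compound 1 to compound 4 (0.30 log units; within the scatter), so piperidin-1-yl and thiomorpholin-4-yl cannot be told apart here, and the ring sulfur can be absent without a step beyond the scatter. Nothing given here explains this result.

Going by these compounds, whether morpholin-4-yl, with oxygen in the place of that sulfur, or an open-chain dimethylamino group on the thiocarbonyl carbon would read any differently remains open. So does the effect of hydrogen in place of methyl on the aromatic carbon when piperidin-1-yl is present.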